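Compound 4: bromo in place of furan-2-yl

The source may report more compounds than this note shows. Statements on the series, on what has been measured and on what is new or still open speak of the compounds shown alone.

Measured in an ADME assay on J774.A1 cells (Mus musculus) for cytotoxicity, read by MTT assay, with a stated time of 72 h; a lower number here means that less compound is tolerated, a higher number that more compound is tolerated:
- compound 1 `CC1(Cc2ccccc2)CC(S(=O)(=O)c2cccc(F)c2)=C(c2ccc(/C(N)=N\O)cc2)O1`: 28300 nM
- compound 2 `CC1(c2ccc(-c3ccco3)cc2)CC(S(=O)(=O)c2ccc(F)cc2)=C(c2ccc(/C(N)=N\O)cc2)O1`: 4560 nM
- compound 3 `CC1(Cc2ccccc2)CC(S(=O)(=O)c2c(F)cccc2F)=C(c2ccc(/C(N)=N\O)cc2)O1`: 27000 nM

Compound 2 has the lowest number of the three, and compound 1 and compound 3 both lie higher by more than the scatter. Compound 4 `CC1(c2ccc(Br)cc2)CC(S(=O)(=O)c2ccc(F)cc2)=C(c2ccc(/C(N)=N\O)cc2)O1` is still unmeasured and departs from compound 2 in one place: bromo in place of furan-2-yl on an aromatic carbon, para to a large group (bromo in place of furan-2-yl on an aromatic carbon). Within the data shown here, the only measured single-place step is a 1.0-fold lower number from compound 1 to compound 3 (0.02 log units; within the scatter). It concerns the group on a sulfonyl sulfur, so it gives no size for the change at this position. Among the measured compounds shown here, compound 2, the only measured compound with furan-2-yl, stands at 4560 nM, whereas compound 1 stands at 28300 nM, but those two differ in more than one place. That gap offers only weak support for a move upward. The expected result is a modest move to a higher number, a 2.0-fold higher number from compound 2 to compound 4 (0.30 log units; within the scatter), and a step within the scatter remains possible. For compound 4 the estimated value is 9000 nM, with an expected range of 3500 nM to 24000 nM.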

Compound 4, half-maximal cytotoxic concentration: 10500 nM
Estimate against measurement, compound 4: 1.2-fold (0.07 log units) below, within the range that was stated.
By their numbers in this assay, from the lowest: compound 2; then compound 4; then compounds 3 and 1 (each within the scatter of the next).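

In this assay, the change from 4-(furan-2-yl)phenyl to 4-bromophenyl gives a 2.3-fold higher number from compound 2 to compound 4 (0.36 log units; beyond the scatter), the first single-place step read at this position. The group para to a large group therefore affects the tolerated concentration, whereas the earlier single-place step concerned only the group on a sulfonyl sulfur. This single pair gives a direction and a modest size, with furan-2-yl on the lower side and bromo on the higher, but no trend, and no measured property bears on the step.

Still open, from the compounds shown here alone, is whether the step follows the departure of furan-2-yl or the arrival of bromo, which a plain hydrogen, chloro or methoxy at this place could help separate. Also open, going by these compounds, is whether another five-membered aromatic ring, such as thiophene, or an amine would sit nearer compound 2 or compound 4.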